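Putting methoxy in place of a larger group on the carbonyl

The source may report more compounds than this note shows. Statements on the series, on what has been measured and on what is new or still open speak of the compounds shown alone.

The compounds here share one core and were tested in a functional assay on MCF7 cells (Homo sapiens) for inhibition, read by sulforhodamine B assay, with a stated time of 72 h; on this read-out higher numbers stand for weaker inhibition of growth and lower numbers for stronger inhibition of growth. Compound 1 (`CN1CCN(C(=O)/C=C/c2ccncc2-c2ccc3ccccc3c2)CC1`) gives > 10000 nM, which is a limit of the assay and not a number. Compound 3 (`COC1CN(C(=O)/C=C/c2ccncc2-c2ccc3ccccc3c2)C1`) gives > 10000 nM, which is also only a limit. Compound 2 (`CCOC(=O)/C=C/c1ccncc1-c1ccc2ccccc2c1`), the only one of the three with a true number, gives 8320 nM.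

Compound 4 (`COC(=O)/C=C/c1ccncc1-c1ccc2ccccc2c1`) has methoxy in place of 3-methoxyazetidin-1-yl on a carbonyl carbon. The closest guide is an at least 1.2-fold higher number from compound 2 to compound 3 (0.07 log units; that floor lies within the scatter), with an at least 1.2-fold lower number from compound 1 to compound 2 (0.07 log units; that floor lies within the scatter) as its companion. Both are only floors, and a step that the two limits leave unreadable from compound 1 to compound 3 gives no usable size. Methoxy in compound 4 stands where ethoxy stands in compound 2, so the expectation leans on compound 2 at 8320 nM. The estimated change is an at least 1.2-fold lower number from compound 3 to compound 4 (0.09 log units; that floor lies within the scatter), a small move towards a lower number that may stay within the scatter. For compound 4 the expected value is 8000 nM, with an estimated range of 4000 nM to 16000 nM.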

Compound 4, concentration for 50% growth inhibition: 8170 nM
The estimate for compound 4 lay 1.0-fold (0.01 log units) below the measured number; low and high end bracket the measured number.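

Replacing ethoxy with methoxy on this carbonyl carbon gives no readable change in growth inhibition: a 1.0-fold lower number from compound 2 to compound 4 (0.01 log units; within the scatter). Compound 4 thus adds a second true number for an ester, and it sets new floors against the two amides: an at least 1.2-fold lower number from compound 3 to compound 4 (0.08 log units; that floor lies within the scatter), and an at least 1.2-fold lower number from compound 1 to compound 4 (0.08 log units; that floor lies within the scatter). These steps are only floors because compound 1 and compound 3 each stop at a limit of the assay, not at a number: the limit of > 10000 nM in this assay, at which 2 of the 4 values shown sit.

Going by these compounds, how the number would respond to a longer chain on the ester oxygen, or to a carboxylic acid at this carbonyl carbon, remains open. On these data alone, the true distance between the two esters and the two amides also remains open, as the limit hides it.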